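Dimethylamino on the arylidene of a thiazolyl-pyrazolone series

A few compounds are considered here, and "the series" means these few. Any claim that something is new, unique, unknown or untested is made for them only; others in the source may bear on it.

The series shares one core, carried by compound 1 `Cc1c(-c2csc(/N=c3\sc(-c4ccccc4)nn3-c3ccccc3)n2)c(=O)n(-c2ccccc2)n1C`, compound 2 `CC(=O)c1nn(-c2ccc([N+](=O)[O-])cc2)/c(=N/c2nc(-c3c(C)n(C)n(-c4ccccc4)c3=O)cs2)s1` and compound 3 `Cc1c(-c2csc(/N=C3\S/C(=C\c4ccccc4)C(=O)N3c3ccccc3)n2)c(=O)n(-c2ccccc2)n1C`, all tested in a functional assay on MCF7 cells (Homo sapiens) for cytotoxicity, read by sulforhodamine B assay, with a stated time of 72 h; a higher number here means a weaker inhibitor, a lower number a stronger inhibitor. For compound 1 the assay returns only a limit, > 100000 nM. Compound 2 likewise gives only a limit, > 100000 nM. Compound 3 also stands at a limit in this assay, > 100000 nM, and nothing more precise is known of it. Within the data shown here, no step between measured compounds is available; the one common feature is the limit of > 100000 nM in this assay, at which 3 of the 3 values shown sit. Compound 4 `Cc1c(-c2csc(/N=C3\S/C(=C\c4ccc(N(C)C)cc4)C(=O)N3c3ccccc3)n2)c(=O)n(-c2ccccc2)n1C` is not yet measured. It differs from compound 3 by dimethylamino in place of hydrogen on an aromatic carbon of the arylidene ring. Among the measured compounds shown here, with no measured step to lean on, and with compound 3 itself at the limit, no shift beyond the scatter is expected in this assay. The step from compound 3 to compound 4 is estimated as a number no higher from compound 3 to compound 4 (the limit leaves the size open). Compound 4 is therefore expected to give about 100000 nM, with a plausible span from 30000 nM to 300000 nM, and most likely once more only a limit.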

Compound 4, half-maximal inhibitory concentration: > 100000 nM
Compound 4 ended at the assay's limit; the forecaster's own chance of this, stated with the estimate: 75%; the middle value sits exactly at the limit.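

The step between compound 3 and compound 4 cannot be read: both values are limits in this assay. The compounds shown leave open what dimethylamino in place of hydrogen changes, and whether any compound of the series gives a measurable value, the one common feature being: the limit of > 100000 nM in this assay, at which 4 of the 4 values shown sit.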